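Compound 1 to compound 3: carboxy to methoxycarbonyl

The source may hold more compounds than are shown below. What is called first, only, known or untested is meant among the compounds shown, and "the series" means these compounds.

Values in a functional assay on the whole organism with Scenedesmus acutus as the target (on this read-out lower numbers stand for stronger inhibition and higher numbers for weaker inhibition), so far
- compound 1 `O=C(O)c1cc(N2C(=O)C3=C(CCCC3)C2=O)c(F)cc1Cl` gives 759 nM
- compound 2 `O=C(O)c1cc(N2C(=O)C3=C(CCCC3)C2=O)ccc1Cl` gives > 100000 nM as a limit

For the measured compounds named here, compound 1 holds the only true number so far. Compound 3 `COC(=O)c1cc(N2C(=O)C3=C(CCCC3)C2=O)c(F)cc1Cl` differs from it by methyl in place of hydrogen on an oxygen next to a carbonyl group with methyl in place of hydrogen on an oxygen next to a carbonyl group. Going by the values given here, the one measured step is an at least 130-fold higher number from compound 1 to compound 2 (2.11 log units; beyond the scatter) for hydrogen in place of fluoro on an aromatic carbon, elsewhere on the shared core. That step runs into the limit of > 100000 nM in this assay, at which 1 of the 2 values shown sits, and so gives only a limit. It shows that one change can matter greatly in this series, but it does not touch the carboxy group. Only a modest step is therefore expected in this assay with no firm direction, possibly none beyond the scatter. For compound 3 the expected value is 500 nM within an estimated range of 80 nM to 4000 nM on this read-out.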

Compound 3, half-maximal inhibitory concentration: 110 nM
Compound 3: middle estimate off by 4.5-fold (0.66 log units), on the high side, and the stated range covers the measured number.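

Methoxycarbonyl in place of carboxy gives a 6.9-fold lower number from compound 1 to compound 3 (0.84 log units; beyond the scatter) in this assay. The hydrogen on this oxygen is therefore not needed for inhibition on the shared core, and replacing it with methyl strengthens inhibition on this read-out. Nothing at hand accounts for the size or direction of this step.

Still open, on these data alone, is whether a longer chain such as ethyl or propyl in place of the methyl continues this trend, or whether an amide in place of the methoxycarbonyl retains it. Also open, as far as these compounds go, is whether methoxycarbonyl retains inhibition with hydrogen in place of fluoro.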